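Replacing Ethoxy with Diethylamino on Compound 1

This account rests on a few compounds, and the source may have more. Where it says the series, first, only, none or still open, it means among the compounds named here.

Compound 1 `CCOc1ccc(C(=O)/C=C/c2c(/C=C/c3ccc(OC)cc3)cc(OC)cc2OC)cc1` was tested in a functional assay on HepG2 cells (Homo sapiens) for antiproliferative activity, read by MTT assay, with a stated time of 48 h (a higher number here means a weaker inhibitor, a lower number a stronger inhibitor), where compound 1 gives 8 ug/mL. Among the three numbers shown it stands second highest. Its nearest neighbour is compound 3 `COc1ccc(/C=C/c2cc(OC)cc(OC)c2/C=C/C(=O)c2ccc(F)cc2)cc1`, which in this assay gives 12.2 ug/mL; the step of a 1.5-fold higher number from compound 1 to compound 3 (0.18 log units; within the scatter) lies within the scatter. Furthest away is compound 2 `COc1ccc(/C=C/c2cc(OC)cc(OC)c2/C=C/C(=O)c2ccc(C)cc2C)cc1`, which gives 0.9 ug/mL in this assay; here an 8.9-fold lower number from compound 1 to compound 2 (0.95 log units; beyond the scatter), the only step beyond the scatter in this set.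

The step now followed leads from compound 1 to compound 4 `CCN(CC)c1ccc(C(=O)/C=C/c2c(/C=C/c3ccc(OC)cc3)cc(OC)cc2OC)cc1`, whose structure differs in one place: diethylamino in place of ethoxy on an aromatic carbon. Among the measured compounds shown here, no measured step involves diethylamino. The closest comparison is the exchange of ethoxy for fluoro on an aromatic carbon, a 1.5-fold higher number from compound 1 to compound 3 (0.18 log units; within the scatter), which lies within the scatter, whereas the larger step of an 8.9-fold lower number from compound 1 to compound 2 (0.95 log units; beyond the scatter) put 2,4-dimethylphenyl in place of 4-ethoxyphenyl on a carbonyl carbon and does not carry over to this change. On that basis a step of no more than the usual scatter is expected in this assay, in either direction. For compound 4 the estimate is 6 ug/mL, with a range from 2 ug/mL to 18 ug/mL. From compound 1 the expected step is a 1.3-fold lower number from compound 1 to compound 4 (0.12 log units; within the scatter).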

Compound 4, half-maximal inhibitory concentration: 6.3 ug/mL
For compound 4 the middle estimate is 1.1-fold (0.02 log units) below the measured one, and the stated range covers the measured number.
By their numbers in this assay, from the lowest: compound 2; then compounds 4, 1 and 3 (each within the scatter of the next).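

In this assay, the aromatic carbon para to a large group now carries three different groups, and the read-out does not separate them: diethylamino compares with ethoxy within the scatter (a 1.3-fold lower number from compound 1 to compound 4 (0.10 log units; within the scatter)) and with fluoro within the scatter as well (a 1.9-fold lower number from compound 3 to compound 4 (0.29 log units; within the scatter)). The earlier compounds had shown this only for the exchange of ethoxy and fluoro, whereas the new step brings in a nitrogen-linked group of 5 heavy atoms in place of an oxygen-linked group of 3, with no step beyond the scatter at this place. Among the compounds shown here, the 4-(diethylamino)phenyl group also leaves compound 2 apart (a 7.0-fold higher number from compound 2 to compound 4 (0.85 log units; beyond the scatter)), so that among the four compounds only the one bearing 2,4-dimethylphenyl gives a number beyond the scatter of the others.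

On these data alone, it remains open whether a carboxylic acid or a longer alkoxy chain at this place would also stay within the scatter, and whether an aromatic ring carrying only one of the two methyl groups of 2,4-dimethylphenyl would match compound 2. Nothing among the data given accounts for why these numbers fall as they do.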